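Adding a chloro to a weak anilide

The source may report more compounds than this note shows. Statements on the series, on what has been measured and on what is new or still open speak of the compounds shown alone.

Compound 1 `O=C(CCCCC(S)CCS)NO`: 58%
Compound 2 `O=C(CCCCC(S)CCS)Nc1ccccc1`: 15.8%

Among the measured compounds shown here, in a functional assay on KB cells (Homo sapiens) for inhibition, read by MTT assay, with a stated time of 24 h, tested at 100 ug/mL (on this read-out higher numbers stand for more inhibition of growth at the one concentration tested and lower numbers for less inhibition of growth), compound 2 gives 15.8%, the lower of the two numbers so far, while compound 1 gives 58%. Compound 3 `O=C(CCCCC(S)CCS)Nc1cccc(Cl)c1` keeps everything in compound 2 except one spot: chloro in place of hydrogen on an aromatic carbon. In words, this is chloro in place of hydrogen on an aromatic carbon, meta to a large group.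

For the measured compounds named here, only one measured step offers any guide: a number 42.2 percentage points lower from compound 1 to compound 2 (beyond the scatter). This large step, beyond the scatter, came with phenyl in place of hydroxy on an amide-type nitrogen. That swap replaces the whole group on the nitrogen, whereas the new change adds a single atom to the phenyl ring. Going by the values given here, no measured compound carries anything on that ring, so the data give no direct size for this step. A much smaller change than the earlier one is therefore expected, probably within the scatter, with a slight upward lean at most. The expected step is a number 4.2 percentage points higher from compound 2 to compound 3 (within the scatter). Compound 3 is estimated at 20%, with an expected range from 8% to 38%.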

Compound 3, percent growth inhibition at one concentration: 8.04%
Estimate against measurement, compound 3: 12 percentage points above, and the stated range covers the measured number.
By their numbers in this assay, from the lowest: compounds 3 and 2 (each within the scatter of the next); then compound 1.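

In this assay, adding a chloro to the aromatic ring, meta to a large group, gives a number 7.8 percentage points lower from compound 2 to compound 3 (within the scatter), so compound 2 and compound 3 cannot be told apart on this read-out. Among the compounds shown here, this is the first measured change on the ring itself, and it shows that this single chlorine atom, at this one place, does not lift the anilide out of its weak range. Its step is small beside a number 42.2 percentage points lower from compound 1 to compound 2 (beyond the scatter), where the whole group on the nitrogen was replaced, so among these compounds only the change on the nitrogen has a clear effect, and no other measurement here bears on this result.

The compounds shown leave open whether a different group on this ring, such as a methoxy, an amine or a carboxylic acid, would move the number beyond the scatter, and whether a chloro placed elsewhere on the ring would do so. They also leave open how a longer chain in the shared core would behave, with either the anilide or the hydroxy group on the nitrogen.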